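The source may hold more compounds than are shown below. What is called first, only, known or untested is meant among the compounds shown, and "the series" means these compounds.

In a functional assay on MDA-MB-231 cells (Homo sapiens) for cytotoxicity, read by sulforhodamine B assay, with a stated time of 72 h (on this read-out lower numbers stand for stronger inhibition of growth and higher numbers for weaker inhibition of growth), compound 1 `O=C(Nc1ccccc1O)C1CCc2ccccc2N1C(=O)c1ccccc1Cl` gives 47400 nM, whereas compound 2 `O=C(Nc1ccccc1O)C1CCc2ccccc2N1C(=O)c1ccccc1` gives 4210 nM. Going by the values given here, the one step connecting them, an 11-fold lower number from compound 1 to compound 2 (1.05 log units; beyond the scatter), comes from removing the chloro from the benzoyl group and is well beyond the usual scatter. Among the compounds with values here, compound 2 therefore holds the lowest of the two numbers measured so far, with compound 1 as its only neighbour at the higher number.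

Compound 3 `O=C(Nc1ccccc1O)C1CCc2ccccc2N1` carries the change (hydrogen in place of benzoyl on a nitrogen on an aromatic ring in a ring). Within the data shown here, the only measured step touches this same benzoyl group but merely alters its substituent, so it bears on the present change only loosely: it shows the group is sensitive to editing, yet says nothing about losing it entirely. Among the measured compounds shown here, with no direct precedent, removing the whole group is expected to weaken growth inhibition, giving an estimated step of a 3.6-fold higher number from compound 2 to compound 3 (0.55 log units; beyond the scatter). For compound 3 the expected value is 15000 nM, within a range from 3000 nM to 70000 nM.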

Compound 3, concentration for 50% growth inhibition: 5260 nM
Beside the measured number, compound 3's estimate is 2.9-fold (0.46 log units) above it; the measured number falls inside the stated range.
By their numbers in this assay, from the lowest: compounds 2 and 3 (each within the scatter of the next); then compound 1.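

In this assay the whole benzoyl group can give way to hydrogen on this nitrogen, with a 1.2-fold higher number from compound 2 to compound 3 (0.10 log units; within the scatter) so the growth inhibition seen here does not depend on that group. Replacing the (2-chlorophenyl)carbonyl group with hydrogen gives a 9.0-fold lower number from compound 1 to compound 3 (0.95 log units; beyond the scatter) and this ties the weak result of compound 1 to its chloro-bearing group, not to the shared core. No measurement available here explains why the chloro-bearing group stands apart.

Still open, going by these compounds, is whether a smaller group on this nitrogen, such as acetyl or methyl, would match compound 3 or move the number beyond the scatter. Also open, on these data alone, is whether a fluoro or a methoxy on the benzoyl ring would raise the number as the chloro does.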